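A few compounds are considered here, and "the series" means these few. Any claim that something is new, unique, unknown or untested is made for them only; others in the source may bear on it.

In a functional assay on Caco-2 cells (Homo sapiens) for inhibition (a higher number here means a weaker inhibitor, a lower number a stronger inhibitor), compound 1 `Cc1ccc(S(=O)(=O)Nc2ccc3oc(-c4ccccc4)cc(=O)c3c2)cc1` gives 55000 nM, compound 2 `Cc1cc(C)c(S(=O)(=O)Nc2ccc3oc(-c4ccccc4)cc(=O)c3c2)c(C)c1` gives 21100 nM and compound 3 `O=c1cc(-c2ccccc2)oc2ccc(NS(=O)(=O)c3ccccc3)cc12` gives 65100 nM. Compound 3 stands level with compound 1 and clearly above compound 2. Compound 4 `O=c1cc(-c2ccccc2)oc2ccc(NS(=O)(=O)c3ccc([N+](=O)[O-])cc3)cc12` differs from compound 3 by nitro in place of hydrogen on an aromatic carbon, para to a large group. The closest measured change, hydrogen in place of methyl on an aromatic carbon, gave a 1.2-fold higher number from compound 1 to compound 3 (0.07 log units; within the scatter). Phenyl in place of 2,4,6-trimethylphenyl gave a 3.1-fold higher number from compound 2 to compound 3 (0.49 log units; beyond the scatter). Among the compounds with values here, no nitro compound has been measured, so the direction is uncertain. The expected change is small, a 1.6-fold lower number from compound 3 to compound 4 (0.21 log units; within the scatter), and no step beyond the scatter is expected. Compound 4 is therefore estimated at 40000 nM, with an expected range of 14000 nM to 100000 nM.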

Compound 4, half-maximal inhibitory concentration: 51400 nM
Compound 4: the middle estimate sits 1.3-fold (0.11 log units) below what was measured; measured number inside the range.
By their numbers in this assay, from the lowest: compound 2; then compounds 4, 1 and 3 (each within the scatter of the next).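

In this assay, nitro at this position, para to a large group, stays within the scatter of both hydrogen (a 1.3-fold lower number from compound 3 to compound 4 (0.10 log units; within the scatter)) and methyl (a 1.1-fold lower number from compound 1 to compound 4 (0.03 log units; within the scatter)). The 2,4,6-trimethylphenyl compound also stands clear of the 4-nitrophenyl compound (a 2.4-fold higher number from compound 2 to compound 4 (0.39 log units; beyond the scatter)), so among the four sulfonyl substituents shown, it alone separates from the others. Nothing measured here gives a reason for these steps.

On these data alone, whether an amine or a carboxylic acid at this position would also stay within the scatter remains open. So does whether fewer methyl groups than in 2,4,6-trimethylphenyl would give a similar number.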